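The compounds below may be only part of what the source reports. "The series", "measured", "known", "first", "only" and "open" are said of these compounds alone.

Measured compounds and their values:

Compound 1, `Cc1c(C(=O)N=C(N)N)cc(S(C)(=O)=O)c(Cl)c1[N+](=O)[O-]`: 44 nM
Compound 2, `CCCc1cc(C)c(C(=O)N=C(N)N)cc1S(C)(=O)=O`: 5.7 nM
Compound 3, `Cc1ccc(-c2ccc(C(=O)N=C(N)N)cc2S(C)(=O)=O)cc1`: 100 nM

In a functional assay for inhibition of sodium/hydrogen exchanger (Oryctolagus cuniculus) (a higher number here means a weaker inhibitor, a lower number a stronger inhibitor), compound 2 gives the lowest of the three numbers. The number for compound 1 lies above it by a margin beyond the usual scatter, and the number for compound 3 lies further above still, also beyond the scatter. Among these three, compound 2 is therefore the strongest inhibitor.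

Compound 4, `CSc1cc(C)c(C(=O)N=C(N)N)cc1S(C)(=O)=O`, has not yet been measured in this assay. It differs from compound 2 in one place: methylsulfanyl in place of propyl on an aromatic carbon. Among the measured compounds shown here, no pair of measured compounds shows this exact change, so there is no measured step to lean on, and the expectation rests on the value of compound 2 alone.

Because compound 2 gives 5.7 nM, compound 4 is expected to stay in the same region, with a small step of a 1.8-fold higher number from compound 2 to compound 4 (0.24 log units; within the scatter) that may well lie within the scatter, leaning if anything toward a slightly higher number. The estimate for compound 4 in this assay is 10 nM, with a range from 3 nM to 35 nM.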

Compound 4, half-maximal inhibitory concentration: 6 nM
Compound 4: middle estimate off by 1.7-fold (0.22 log units), on the high side, and the stated range covers the measured number.
By their numbers in this assay, from the lowest: compounds 2 and 4 (each within the scatter of the next); then compound 1; then compound 3.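

In this assay, among the compounds shown here, methylsulfanyl in place of propyl on this aromatic carbon gives a 1.1-fold higher number from compound 2 to compound 4 (0.02 log units; within the scatter), the first step that isolates a single position. At this place, ortho to a methylsulfonyl group, the two groups cannot be told apart, although one is a carbon chain with no hydrogen-bond acceptor and the other carries sulfur and counts one acceptor; compounds 1 and 3 differ from compound 2 in more than one place and could not show this. No measured evidence here bears on why the two compounds read alike.

From the compounds shown here alone, whether other groups on this carbon, such as an amine, a methoxy group or a longer chain like pentyl, would also stay within the scatter remains open. So does whether methylsulfanyl would read the same with the other substituents of the shared core changed.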